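The source may report more compounds than this note shows. Statements on the series, on what has been measured and on what is new or still open speak of the compounds shown alone.

Measured so far:
compound 1, `CS(=O)(=O)N1CCN(CC(O)CN2CCC(CNC(=O)c3cccc4[nH]c(C5CC5)nc34)CC2)CC1`: 0.631 nM
compound 2, `CC(C)(C)c1nc2c(C(=O)NCC3CCN(CC(O)CN4CCN(S(C)(=O)=O)CC4)CC3)cccc2[nH]1`: 3.16 nM
compound 3, `CC(C)c1nc2c(C(=O)NCC3CCN(CCN4CCN(S(C)(=O)=O)CC4)CC3)cccc2[nH]1`: 0.794 nM

All three were examined in a functional assay for agonist activity at 5-hydroxytryptamine receptor 4 (Homo sapiens), read by cAMP accumulation; on this read-out higher numbers stand for an effect only at larger amounts of compound and lower numbers for an effect already at smaller amounts. Compound 3 gives 0.794 nM. Its nearest neighbour is compound 1, which gives 0.631 nM, a gap within the scatter, so the two cannot be told apart. Compound 2 gives 3.16 nM, a number beyond the scatter higher than that of compound 3. Among the measured compounds shown here, the only step between compounds that differ in one place is a 5.0-fold higher number from compound 1 to compound 2 (0.70 log units; beyond the scatter), and that change concerns the small group on the shared core.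

Compound 4, `CC(=O)N1CCN(CCN2CCC(CNC(=O)c3cccc4[nH]c(C(C)C)nc34)CC2)CC1`, has not yet been measured. It differs from compound 3 in one place: acetyl in place of methylsulfonyl on an amine nitrogen in a ring. For the measured compounds named here, no measured pair among the three compounds alters this part of the molecule; the single measured step concerns another position and gives no guidance on the size or direction of an effect here. With no evidence either way, the expectation is that the number stays close to that of compound 3, within the usual scatter, though the uncertainty is wide. For compound 4 the expected step is a 1.3-fold higher number from compound 3 to compound 4 (0.10 log units; within the scatter). The estimate for compound 4 in this assay is therefore 1 nM, with a range from 0.3 nM to 3.5 nM.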

Compound 4, half-maximal effective concentration: 3.16 nM
The estimate for compound 4 lay 3.2-fold (0.50 log units) below the measured number; the range from low to high includes it.
By their numbers in this assay, from the lowest: compounds 1 and 3 (each within the scatter of the next); then compounds 2 and 4 (each within the scatter of the next).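

Among the compounds shown here, until now, the only measured change was to the small group on the shared core, so this is the first sign that in this assay the group on the amine nitrogen in a ring also matters: acetyl in place of methylsulfonyl gives a 4.0-fold higher number from compound 3 to compound 4 (0.60 log units; beyond the scatter). The swap looks minor on paper, since methylsulfonyl has 4 heavy atoms and 2 hydrogen-bond acceptors and acetyl has 3 heavy atoms and 1 hydrogen-bond acceptor, while neither has a ring, a hydrogen-bond donor or a net charge, yet the step lies beyond the scatter. Nothing measured here explains which of these differences lies behind the step.

On these data alone, this is a single pair, so whether the same swap would give a step of similar size on compounds with cyclopropyl or tert-butyl on the shared core remains open. It is also unknown whether a plain methyl, an ethylsulfonyl or a methoxycarbonyl on that nitrogen would give a number closer to that of compound 3 or to that of compound 4.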